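Hydroxy for chloro on a cyanoacrylamide cytotoxicity series

The source may report more compounds than this note shows. Statements on the series, on what has been measured and on what is new or still open speak of the compounds shown alone.

Measured so far:
compound 1, `Cc1ccc2nc(C)n(NC(=O)CC#N)c(=O)c2c1`, gives 30000 nM in a functional assay on HeLa cells (Homo sapiens) for cytotoxicity, read by MTT assay, with a stated time of 3 days; on this read-out lower numbers stand for stronger inhibition and higher numbers for weaker inhibition.
compound 2, `Cc1ccc2nc(C)n(NC(=O)/C(C#N)=C/c3ccc(Cl)cc3)c(=O)c2c1`, gives 12000 nM in this assay.

Of the two numbers seen, compound 2 holds the lower one, and the gap to compound 1 lies beyond the usual scatter, so compound 2 is the stronger of the pair on this read-out. Compound 3, `Cc1ccc2nc(C)n(NC(=O)/C(C#N)=C/c3ccc(O)cc3)c(=O)c2c1`, has not yet been measured. It differs from compound 2 in one place only: hydroxy in place of chloro on an aromatic carbon. Going by the values given here, no change of this kind has been measured within this set, so there is no step to lean on; what remains is the single measured difference between compound 1 and compound 2, which concerns a different part of the molecule.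

With that little to go on, the expected step from compound 2 to compound 3 is small, a 1.3-fold higher number from compound 2 to compound 3 (0.10 log units; within the scatter), and could fall on either side of the scatter. The estimate for compound 3 is 15000 nM, with a range from 5000 nM to 50000 nM.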

Compound 3, half-maximal inhibitory concentration: 13000 nM
Estimate against measurement, compound 3: 1.2-fold (0.06 log units) above; the measured number falls inside the stated range.
By their numbers in this assay, from the lowest: compounds 2 and 3 (each within the scatter of the next); then compound 1.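

In this assay the exchange of chloro for hydroxy on the aromatic ring, 4-chlorophenyl to 4-hydroxyphenyl, gives a 1.1-fold higher number from compound 2 to compound 3 (0.03 log units; within the scatter) and so places compound 2 and compound 3 within the scatter of each other. Going by these compounds alone, this is the first reading of any change at this position, since compound 1 has no such ring and could say nothing about what sits on it. Here, a group with one hydrogen-bond donor and one hydrogen-bond acceptor takes the place of one with neither, and this read-out does not separate the two compounds; no data shown here explain why the pair reads alike.

This rests on a single pair, so it cannot show whether the position accepts changes in general or whether these two groups merely happen to read alike. A plain phenyl ring with hydrogen at this position, or an amine, a methoxy group or a carboxylic acid in the same place, could read alike or differently, and the same holds for a hydroxy group elsewhere on the ring.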